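From 1-Methylethenyl to Butyl on the Amide Carbonyl

This account rests on a few compounds, and the source may have more. Where it says the series, first, only, none or still open, it means among the compounds named here.

Compound 1, `C=C(C)C(=O)N(Cc1ccc(OC)c(O)c1)c1cc(OC)c(OC)c(OC)c1`: 390 nM
Compound 3, `C/C=C/C(=O)N(Cc1ccc(OC)c(OC)c1)c1cc(OC)c(OC)c(OC)c1`: 20100 nM
Compound 2, `COc1ccc(CNc2cc(OC)c(OC)c(OC)c2)cc1F`: 39700 nM

Of the compounds shown here, three have been measured in a functional assay on MGC-803 cells (Homo sapiens) for inhibition, read by MTT assay, with a stated time of 48 h; a lower number here means a stronger inhibitor, a higher number a weaker inhibitor. Compound 1 stands lowest of the three by a wide margin: compound 3 and compound 2 both give numbers far above it, well beyond the usual scatter, so compound 1 is clearly the strongest inhibitor of the set.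

Compound 4, `CCCCC(=O)N(Cc1ccc(OC)c(O)c1)c1cc(OC)c(OC)c(OC)c1`, differs from compound 1 in one place: butyl in place of 1-methylethenyl on a carbonyl carbon. Within the data shown here, no measured pair isolates this change. Compound 3 carries a different group on the carbonyl but also differs from compound 1 elsewhere, so its much higher number cannot be tied to the carbonyl substituent alone. With the shared core and the hydroxy-bearing benzyl group kept, compound 4 is expected to remain a real inhibitor, but the loss of the double bond is expected to cost potency, giving an upward step of a 7.7-fold higher number from compound 1 to compound 4 (0.89 log units; beyond the scatter) beyond the scatter. Compound 4 is therefore estimated at 3000 nM, within a range from 600 nM to 15000 nM.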

Compound 4, half-maximal inhibitory concentration: 66 nM
Estimate against measurement, compound 4: 45-fold (1.66 log units) above; measured number outside the range, below it.
By their numbers in this assay, from the lowest: compound 4; then compound 1; then compounds 3 and 2 (each within the scatter of the next).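

Among these compounds, this pair is the first to isolate the group on the amide carbonyl: with everything else held the same, in this assay the change to butyl gives a 5.9-fold lower number from compound 1 to compound 4 (0.77 log units; beyond the scatter). The double bond of 1-methylethenyl is therefore not needed for inhibition in this series, and a chain without one goes with a stronger inhibitor, so the position accepts more than one kind of carbon group. No measurement here explains why the number falls, so the step stands as an observation without a known cause.

As far as these compounds go, it remains open whether a longer chain such as hexyl, or a ring such as cyclohexyl, on the same carbonyl would give a lower or a higher number. A single pair also cannot show whether butyl brings the same gain on a different benzyl group, or how a chain ending in an amine would behave.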